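Compound 3: a smaller group on the oxygen

This account rests on a few compounds, and the source may have more. Where it says the series, first, only, none or still open, it means among the compounds named here.

- Compound 1 `O=C(Nc1cccc(C(F)(F)F)c1)N[C@H]1CC[C@H](Oc2ccc(C(F)(F)F)cc2)CC1`: 660 nM
- Compound 2 `O=C(Nc1cccc(C(F)(F)F)c1)N[C@H]1CC[C@H](Oc2ccc(OC(F)(F)F)cc2)CC1`: 850 nM

Within the data shown here, in a functional assay on CRL2813 cells (Homo sapiens) for antiproliferative activity, read by sulforhodamine B assay, with a stated time of 3 days, in the presence of a further agent that is not named here (a higher number here means a weaker inhibitor, a lower number a stronger inhibitor), compound 1 has no clear lead, since the only other measured compound lies within the scatter of it. Compound 3 `O=C(Nc1cccc(C(F)(F)F)c1)N[C@H]1CC[C@H](Oc2ccccc2F)CC1` keeps the shared core but differs from compound 1 in one place: 2-fluorophenyl in place of 4-(trifluoromethyl)phenyl on an oxygen on a saturated carbon. Among the measured compounds shown here, the one measured step, a 1.3-fold higher number from compound 1 to compound 2 (0.11 log units; within the scatter), only put trifluoromethoxy in place of trifluoromethyl, so it offers weak guidance for replacing the whole group. A modest rise is expected, though the data cannot settle its direction. The estimated step is a 1.8-fold higher number from compound 1 to compound 3 (0.26 log units; within the scatter). The estimate for compound 3 is 1200 nM, with an expected range of 400 nM to 3600 nM.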

Compound 3, half-maximal inhibitory concentration: 2800 nM
For compound 3 the middle estimate is 2.3-fold (0.37 log units) below the measured one; the range from low to high includes it.
By their numbers in this assay, from the lowest: compounds 1 and 2 (each within the scatter of the next); then compound 3.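

In this assay the group on the oxygen can move the number beyond the scatter: 2-fluorophenyl in place of 4-(trifluoromethyl)phenyl gives a 4.2-fold higher number from compound 1 to compound 3 (0.63 log units; beyond the scatter) while the earlier trifluoromethoxy swap stayed within it. So this position does respond to a change of the whole aromatic group. Nothing shown here explains the rise.

This swap changes both the substituent and where it sits on the ring, so the two cannot be told apart. On these data alone, how 4-fluorophenyl, plain phenyl or a ring carrying an amine would compare remains open.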